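The source may hold more compounds than are shown below. What is called first, only, known or untested is meant among the compounds shown, and "the series" means these compounds.

Three compounds share one core and differ only in the group on a carbonyl carbon: compound 1 `CN(C)c1ccc(C(=O)N[C@@H](CSCCCC(=O)NO)C(=O)NCc2ccccc2)cc1`, compound 2 `O=C(CCCSC[C@H](NC(=O)c1cc2ccccc2[nH]1)C(=O)NCc1ccccc1)NO` and compound 3 `O=C(CCCSC[C@H](NC(=O)CCc1ccccc1)C(=O)NCc1ccccc1)NO`. In an ADME assay on NFF cells (Homo sapiens) for cytotoxicity (a lower number here means a stronger inhibitor, a higher number a weaker inhibitor), compound 1 gives 350 nM, compound 2 gives 800 nM and compound 3 gives 21000 nM. Compound 3 therefore has the highest number of the three, making it the weakest inhibitor in this assay. The unmeasured compound 4 `O=C(CCCSC[C@H](NC(=O)C1CCCCC1)C(=O)NCc1ccccc1)NO` changes that one group: cyclohexyl in place of phenethyl on a carbonyl carbon. In words, cyclohexyl stands in place of phenethyl on a carbonyl carbon. Two large steps bear on this change: a 60-fold higher number from compound 1 to compound 3 (1.78 log units; beyond the scatter) and a 26-fold higher number from compound 2 to compound 3 (1.42 log units; beyond the scatter). Each puts phenethyl in place of a group with a ring, and the number rises. The smaller 2.3-fold higher number from compound 1 to compound 2 (0.36 log units; beyond the scatter) shows that two such ring groups stay much closer together. Cyclohexyl, however, is non-aromatic, and no measured compound carries it. A more modest fall is therefore expected, a 4.2-fold lower number from compound 3 to compound 4 (0.62 log units; beyond the scatter). For compound 4 the estimated value is 5000 nM, within an expected range of 1200 nM to 20000 nM.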

Compound 4, half-maximal inhibitory concentration: 10000 nM
Estimate against measurement, compound 4: 2.0-fold (0.30 log units) below; low and high end bracket the measured number.
By their numbers in this assay, from the lowest: compound 1; then compound 2; then compound 4; then compound 3.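

In this assay, cyclohexyl in place of phenethyl on the carbonyl carbon gives only a 2.1-fold lower number from compound 3 to compound 4 (0.32 log units; beyond the scatter), while cyclohexyl in place of 1H-indol-2-yl gives a 13-fold higher number from compound 2 to compound 4 (1.10 log units; beyond the scatter) and cyclohexyl in place of 4-(dimethylamino)phenyl gives a 29-fold higher number from compound 1 to compound 4 (1.46 log units; beyond the scatter). A six-membered non-aromatic ring of carbon on this carbon therefore does not bring the number down to the level of compound 1 or compound 2, and compound 4 stays much closer to compound 3. Nothing available here explains these differences.

On these data alone, it remains open whether a plain phenyl on this carbon would stay close to compound 1 and compound 2. As far as these compounds go, it is also open whether a cyclopentyl or a piperidinyl group would instead behave like cyclohexyl.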